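The source may hold more compounds than are shown below. What is called first, only, known or untested is meant among the compounds shown, and "the series" means these compounds.

Working notes on the series in an ADME assay on MT4 cells (Homo sapiens) for cytotoxicity; on this read-out lower numbers stand for higher toxicity in this test and higher numbers for lower toxicity in this test: compound 1 `CC[C@H]1CC[C@H](c2ccc(NC(=S)Nc3cccc(C(F)(F)F)c3)cc2)CC1` gives 39000 nM, compound 2 `Fc1ccc(NC(=S)Nc2cccc(C(F)(F)F)c2)cc1Cl` gives 8000 nM, and compound 3 `Fc1ccc(NC(=S)Nc2cccc(C(F)(F)F)c2)cc1` gives 31000 nM. Compound 3 cannot be separated from compound 1, as a 1.3-fold lower number from compound 1 to compound 3 (0.10 log units; within the scatter) shows, and it stands clearly higher than compound 2. The next change leads to compound 4 `FC(F)(F)c1cccc(NC(=S)Nc2ccccc2Br)c1`: 2-bromophenyl in place of 4-fluorophenyl on an amide-type nitrogen. Among the measured compounds shown here, no measured compound carries this group. The nearest guide is a 3.9-fold higher number from compound 2 to compound 3 (0.59 log units; beyond the scatter), a modest step with hydrogen in place of chloro on an aromatic carbon. The expected step in this assay is similarly modest and downward, a 1.9-fold lower number from compound 3 to compound 4 (0.29 log units; within the scatter). Compound 4 is estimated at 16000 nM, with an expected range of 6000 nM to 36000 nM.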

Compound 4, half-maximal cytotoxic concentration: 36000 nM
Beside the measured number, compound 4's estimate is 2.3-fold (0.35 log units) below it, and the stated range covers the measured number.
By their numbers in this assay, from the lowest: compound 2; then compounds 3, 4 and 1 (each within the scatter of the next).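

In this assay, 2-bromophenyl in place of 4-fluorophenyl on an amide-type nitrogen gives a 1.2-fold higher number from compound 3 to compound 4 (0.06 log units; within the scatter), so this exchange of one halogenated phenyl for another cannot be separated from no change. The chloro step, a 3.9-fold higher number from compound 2 to compound 3 (0.59 log units; beyond the scatter), remains the only step shown that lies beyond the scatter. Nothing available accounts for this outcome. The compounds shown leave open whether a phenyl bearing an amine or a carboxylic acid on this nitrogen would stay within the same range. Also open, going by these compounds, is what a carbonyl in place of the thiocarbonyl would do.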